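This account rests on a few compounds, and the source may have more. Where it says the series, first, only, none or still open, it means among the compounds named here.

Measured so far:
- compound 1, `CC(C)=CCC/C(C)=C/CC/C(C)=C/CC[C@@H]1[C@@]2(C)CC/C(=N\OCc3cn(-c4cccc(Br)c4)nn3)C(C)(C)[C@@H]2CC[C@@]1(C)O`, 11700 nM
- compound 2, `CC(C)=CCC/C(C)=C/CC/C(C)=C/CC[C@@H]1[C@@]2(C)CC/C(=N\OCc3cn(-c4ccccc4C#N)nn3)C(C)(C)[C@@H]2CC[C@@]1(C)O`, 20000 nM
- compound 3, `CC(C)=CCC/C(C)=C/CC/C(C)=C/CC[C@@H]1[C@@]2(C)C/C(=C\c3ccc(OCc4cn(-c5ccccc5)nn4)cc3)C(=O)C(C)(C)[C@@H]2CC[C@@]1(C)O`, 100000 nM

All three were tested in a functional assay on A549 cells (Homo sapiens) for cytotoxicity, read by MTT assay, with a stated time of 48 h; a lower number here means a stronger inhibitor, a higher number a weaker inhibitor. Compound 3 gives the highest number of the three in this assay, so on these numbers it is the weakest inhibitor; the step from compound 2 to compound 3 and from compound 1 to compound 3 are both beyond the usual scatter. The new compound is compound 4, `COc1cc(OC)c(-n2cc(COc3ccc(/C=C4\C[C@]5(C)[C@@H](CC/C=C(\C)CC/C=C(\C)CCC=C(C)C)[C@](C)(O)CC[C@H]5C(C)(C)C4=O)cc3)nn2)c(OC)c1`. The change from compound 3 to compound 4 is 2,4,6-trimethoxyphenyl in place of phenyl on an aromatic nitrogen.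

Going by the values given here, only one measured step touches the same place, the aryl group on the ring nitrogen: a 1.7-fold higher number from compound 1 to compound 2 (0.23 log units; within the scatter). That exchange of one aryl group for another, in a different core, produced no step beyond the scatter. The trimethoxyphenyl group has not been tried anywhere in the data, so there is no measured guide for it. Compound 4 is therefore expected to stay close to compound 3, with a 1.3-fold lower number from compound 3 to compound 4 (0.10 log units; within the scatter) expected to be within the scatter. The estimate for compound 4 in this assay is 80000 nM, in the range 25000 nM to 250000 nM.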

Compound 4, half-maximal inhibitory concentration: 16100 nM
The estimate for compound 4 lay 5.0-fold (0.70 log units) above the measured number; measured number below the stated range.
By their numbers in this assay, from the lowest: compounds 1, 4 and 2 (each within the scatter of the next); then compound 3.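

In this assay, 2,4,6-trimethoxyphenyl in place of phenyl on the aromatic nitrogen gives a 6.2-fold lower number from compound 3 to compound 4 (0.79 log units; beyond the scatter). The only other aryl exchange shown, a 1.7-fold higher number from compound 1 to compound 2 (0.23 log units; within the scatter), stayed within the scatter, though it involved different groups on a different core, so this step is the first sign that the aryl group at this position can change the number in this assay. No measurement shown explains why this change lowers the number.

The compounds shown leave open whether all three methoxy groups are needed, or whether a single methoxy group, a hydroxyl or an amine on the phenyl ring would give a similar step. They also leave open whether 2,4,6-trimethoxyphenyl would have the same effect on the core of compound 1.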